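A Second Methoxy Group on an Aryl Sulfonate Scaffold

A few compounds are considered here, and "the series" means these few. Any claim that something is new, unique, unknown or untested is made for them only; others in the source may bear on it.

Compound 1 `COc1ccc(OS(=O)(=O)c2ccc(N3CCN(C)C3=O)cc2)cc1OC` gives 12000 nM in a functional assay on HT-29 cells (Homo sapiens) for antiproliferative activity, read by sulforhodamine B assay, with a stated time of 48 h; a lower number here means a stronger inhibitor, a higher number a weaker inhibitor. Compound 2 `COc1cc(OS(=O)(=O)c2ccc(N3CCN(C)C3=O)cc2)cc(OC)c1OC` differs from compound 1 by a single change, (methoxy in place of hydrogen on an aromatic carbon), and in this assay compound 2 gives 62 nM, so a 190-fold lower number from compound 1 to compound 2 (2.29 log units; beyond the scatter). Compound 3 `CCN1CCN(c2ccc(S(=O)(=O)Oc3cccc(OC)c3)cc2)C1=O` has a different core; how it differs from compound 1 is not broken down here. In this assay compound 3 gives 22000 nM, a value within the scatter of compound 1.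

Compound 4 `CCN1CCN(c2ccc(S(=O)(=O)Oc3cc(OC)cc(OC)c3)cc2)C1=O`, not yet measured, arises from compound 3 by the same kind of change: methoxy in place of hydrogen on an aromatic carbon. The surroundings are not identical, however: in compound 2 the entering methoxy sits ortho to a methoxy group, meta to a large group and meta to a methoxy group, whereas in compound 4 it sits meta to a large group and meta to a methoxy group only. Because a 190-fold lower number from compound 1 to compound 2 (2.29 log units; beyond the scatter), a lower number is expected for compound 4 as well, but a smaller step is estimated, a 7.3-fold lower number from compound 3 to compound 4 (0.87 log units; beyond the scatter), since the two places are not the same. The estimated value for compound 4 in this assay is 3000 nM, with an expected range from 600 nM to 15000 nM.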

Compound 4, half-maximal inhibitory concentration: 4300 nM
Compound 4: middle estimate off by 1.4-fold (0.16 log units), on the low side; low and high end bracket the measured number.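

In this assay, methoxy in place of hydrogen on an aromatic carbon again lowers the number on the second core, with a 5.1-fold lower number from compound 3 to compound 4 (0.71 log units; beyond the scatter), so the direction of the change carries across this one pair of cores. The size of the step does not carry across, as the two steps set side by side make plain: the same change on two cores in this assay, a 190-fold lower number (2.29 log units; beyond the scatter) from compound 1 to compound 2 and a 5.1-fold lower number (0.71 log units; beyond the scatter) from compound 3 to compound 4, 38-fold (1.58 log units) apart, beyond the scatter of two such steps. This does not show what sets the size of the step, since the two pairs differ both in the core and in the groups around the entering methoxy, and two pairs give no rule for a further core.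

The compounds shown include no case of one and the same set of aryl methoxy groups on both cores, which leaves open how much of the gap belongs to the core alone. Also open, on these data alone, is how a hydroxy group or an amine would compare with the entering methoxy, and how a longer chain in place of the ethyl group would fare in this assay.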